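From 3,4,5-Trimethoxyphenyl to 4-Hydroxyphenyl: Expecting Little Change

The source may hold more compounds than are shown below. What is called first, only, known or untested is meant among the compounds shown, and "the series" means these compounds.

In a functional assay on PC-3 cells (Homo sapiens) for cytotoxicity, read by MTT assay, with a stated time of 72 h (a higher number here means a weaker inhibitor, a lower number a stronger inhibitor), compound 3 `COc1cc2ncnc(Nc3ccc(F)c(Cl)c3)c2cc1NC(=O)N/N=C/c1cc(OC)c(OC)c(OC)c1` gives 36500 nM. Compound 1 `COc1cc2ncnc(Nc3ccc(F)c(Cl)c3)c2cc1NC(=O)N/N=C/c1ccc([N+](=O)[O-])cc1` gives 32400 nM, within the scatter of that number, while compound 2 `COc1ccc(/C=N/NC(=O)Nc2cc3c(Nc4ccc(F)c(Cl)c4)ncnc3cc2OC)cc1` gives a lower 16500 nM. Compound 4 `COc1cc2ncnc(Nc3ccc(F)c(Cl)c3)c2cc1NC(=O)N/N=C/c1ccc(O)cc1` has 4-hydroxyphenyl in place of 3,4,5-trimethoxyphenyl on a carbon with a double bond to nitrogen. Three measured steps changed this same aromatic group, and all were small: a 2.0-fold lower number from compound 1 to compound 2 (0.29 log units; within the scatter), a 1.1-fold higher number from compound 1 to compound 3 (0.05 log units; within the scatter) and a 2.2-fold higher number from compound 2 to compound 3 (0.34 log units; beyond the scatter). Going by the values given here, none of the measured compounds carries a hydroxy group, so the direction is uncertain. Only a small change is expected in this assay, namely a 1.5-fold lower number from compound 3 to compound 4 (0.16 log units; within the scatter). For compound 4, the estimated value is 25000 nM, with an expected range from 10000 nM to 55000 nM.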

Compound 4, half-maximal inhibitory concentration: 16600 nM
Compound 4: middle estimate off by 1.5-fold (0.18 log units), on the high side, within the range that was stated.
By their numbers in this assay, from the lowest: compounds 2, 4, 1 and 3 (each within the scatter of the next, the first and the last beyond it).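

The change to 4-hydroxyphenyl gives a 2.2-fold lower number from compound 3 to compound 4 (0.34 log units; beyond the scatter) in this assay, so a hydroxy group at this position can be measured and does not set compound 4 apart from the other compounds. Hydrogen in place of methyl on the oxygen gives a 1.0-fold higher number from compound 2 to compound 4 (0.00 log units; within the scatter), and hydroxy in place of nitro gives a 2.0-fold lower number from compound 1 to compound 4 (0.29 log units; within the scatter), leaving compound 4 within the scatter of both compound 1 and compound 2. Nothing shown here explains these steps. From the compounds shown here alone, whether an amine or a carboxylic acid in place of the hydroxy group would give a clearly larger step stays open.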